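Notes on the step from compound 2 to compound 3

The source may report more compounds than this note shows. Statements on the series, on what has been measured and on what is new or still open speak of the compounds shown alone.

Measured in an ADME assay on microsomes from liver (Rattus norvegicus) for metabolic stability, read by LC-MS, with a stated time of 1 h, at 37 degrees C, tested at 4 uM (on this read-out lower numbers stand for a less stable compound and higher numbers for a more stable compound), so far:
- compound 1 `O=C(O)c1cc(-c2cccc(COc3ccc4c(c3)CN(C3CCCC3)C4=O)c2)ccc1O` gives 9%
- compound 2 `O=C1c2ccc(OCc3cccc(-c4ccc(C(F)(F)F)cc4F)c3)cc2CN1C1CCCC1` gives "not determined" (no result reported)

Among the compounds with values here, compound 2 has no place on the scale of this assay because no result was reported for it, and compound 1 holds the only number. Compound 3 `O=C(O)c1cc(F)cc(-c2cccc(COc3ccc4c(c3)CN(C3CCCC3)C4=O)c2)c1` has not yet been measured. The structural change (3-carboxy-5-fluorophenyl in place of 2-fluoro-4-(trifluoromethyl)phenyl on an aromatic carbon) puts 3-carboxy-5-fluorophenyl in place of 2-fluoro-4-(trifluoromethyl)phenyl on an aromatic carbon, meta to a large group. With no number at its starting end, this step has no size or direction that can be expected in this assay. Within the data shown here, the only guide is compound 1, which also carries a carboxy group on an aromatic ring and gives a low reading (9%). A low reading is therefore expected for compound 3 too, with wide uncertainty from a single reference point. Compound 3 is expected at 15% (estimated range 4% to 40%).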

Compound 3, percent of the compound remaining: 55%
The estimate for compound 3 lay 40 percentage points below the measured number; the whole stated range lies below it.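

In this assay, within the data shown here, 3-carboxy-5-fluorophenyl in place of 3-carboxy-4-hydroxyphenyl on this aromatic carbon gives a number 46 percentage points higher from compound 1 to compound 3 (beyond the scatter), the first readable change at this position. A carboxy group on this ring therefore does not by itself hold the reading low, since the other group on the ring also goes with a clear difference, while the step from compound 2 cannot be read without a number at its starting end. No measurement available here accounts for the size of this step.

The pair leaves open whether removing the hydroxy group or adding the fluorine carries the step, which a plain 3-carboxyphenyl group would help separate. It also leaves open how a nitrile or an amine in place of the carboxylic acid on this ring would read.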